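Chalcone-triazolopyrimidine series: naphthyl replacement at the enone aryl

The source may report more compounds than this note shows. Statements on the series, on what has been measured and on what is new or still open speak of the compounds shown alone.

Measured so far:
compound 1 `COc1ccc(/C=C/C(=O)c2ccc(Nc3cc(C)nc4nc(SCc5nc6ccccc6[nH]5)nn34)cc2)cc1` gives 170 nM in a functional assay on SW-620 cells (Homo sapiens) for cytotoxicity, read by MTT assay, with stated times of 4 h and 72 h, tested at 2 uM; a higher number here means a weaker inhibitor, a lower number a stronger inhibitor
compound 2 `Cc1ccc(/C=C/C(=O)c2ccc(Nc3cc(C)nc4nc(SCc5nc6ccccc6[nH]5)nn34)cc2)cc1` gives 1520 nM in this assay

Compound 2 carries the highest number of the two measured in this assay; its nearest neighbour is compound 1, and the step of an 8.9-fold higher number from compound 1 to compound 2 (0.95 log units; beyond the scatter) is beyond the scatter, so compound 2 reads as the weaker of the pair.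

Compound 3 `Cc1cc(Nc2ccc(C(=O)/C=C/c3ccc4ccccc4c3)cc2)n2nc(SCc3nc4ccccc4[nH]3)nc2n1` is not yet measured in this assay. Relative to compound 2 the change is naphthalen-2-yl in place of 4-methylphenyl on a double-bonded chain carbon bound to a double-bonded chain carbon.

Among the compounds with values here, no measured step covers this exact change. Within the data shown here, the only step known, an 8.9-fold higher number from compound 1 to compound 2 (0.95 log units; beyond the scatter), alters the same double-bonded chain carbon position, and shows that this end of the molecule moves the number well beyond the scatter. Direction for the naphthalen-2-yl group is not constrained by the data. The working expectation is a step of a 2.2-fold lower number from compound 2 to compound 3 (0.34 log units; beyond the scatter), with wide uncertainty. Compound 3 is therefore estimated at 700 nM in this assay, in a range from 200 nM to 3000 nM.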

Compound 3, half-maximal inhibitory concentration: 5 nM
The estimate for compound 3 lay 140-fold (2.15 log units) above the measured number; measured number outside the range, below it.
By their numbers in this assay, from the lowest: compound 3; then compound 1; then compound 2.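

In this assay the group on a double-bonded chain carbon bound to a double-bonded chain carbon can move the number much further than the methoxy-to-methyl change indicated: naphthalen-2-yl in place of 4-methylphenyl gives a 300-fold lower number from compound 2 to compound 3 (2.48 log units; beyond the scatter) and naphthalen-2-yl in place of 4-methoxyphenyl gives a 34-fold lower number from compound 1 to compound 3 (1.53 log units; beyond the scatter) at this position. Both steps are beyond the scatter, which places compound 3 lowest of the three, and the same replacement improves on both single-ring groups. No available measurement bears on the reason for these steps.

As far as these compounds go, whether the gain needs the naphthalen-2-yl attachment or would survive with naphthalen-1-yl remains open. Also open, from the compounds shown here alone, is whether an amine or a carboxylic acid on the naphthalen-2-yl ring would keep the number this low.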